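A few compounds are considered here, and "the series" means these few. Any claim that something is new, unique, unknown or untested is made for them only; others in the source may bear on it.

Compound 1 `O=C1O/C(=C\Cn2cc(Cc3ccccc3)nn2)C(OCc2ccccc2)=C1OCc1ccccc1`: 71300 nM
Compound 2 `O=C1NC(O)(CCn2cc(C3=CCCCC3)nn2)C(OCc2ccccc2)=C1OCc1ccccc1`: 67200 nM
Compound 3 `Cc1ccc(-c2cn(C/C=C3\OC(=O)C(OCc4ccccc4)=C3OCc3ccccc3)nn2)cc1`: > 100000 nM

In a functional assay on PC-3 cells (Homo sapiens) for antiproliferative activity, read by MTT assay, with a stated time of 24 h (on this read-out lower numbers stand for stronger inhibition and higher numbers for weaker inhibition), compound 1 gives 71300 nM and compound 2 gives 67200 nM; these two values lie within the usual scatter of each other, so neither can be set above the other. Compound 3 reaches only the limit of this assay, > 100000 nM, a bound rather than a measured number; this is the limit of > 100000 nM in this assay, at which 1 of the 3 values shown sits. Compound 4 `Cc1ccc(-c2cn(CCC3(O)NC(=O)C(OCc4ccccc4)=C3OCc3ccccc3)nn2)cc1` has not yet been measured. It differs from compound 2 by 4-methylphenyl in place of cyclohex-1-en-1-yl on an aromatic carbon. Among the compounds with values here, the one measured step that bears on this change is an at least 1.4-fold higher number from compound 1 to compound 3 (0.14 log units; that floor lies within the scatter), where 4-methylphenyl also enters on an aromatic carbon, though there it replaces benzyl and sits on a different core. On these data alone, that step pointed toward a higher number but ran into the assay limit, so its true size is unknown. On this basis compound 4 is expected to give a somewhat higher number than compound 2, a 1.5-fold higher number from compound 2 to compound 4 (0.17 log units; within the scatter), with a real chance that only a limit is reported. Compound 4 is therefore estimated at 100000 nM, between 50000 nM and 200000 nM.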

Compound 4, half-maximal inhibitory concentration: 84200 nM
For compound 4 the middle estimate is 1.2-fold (0.07 log units) above the measured one, and the stated range covers the measured number.
By their numbers in this assay, from the lowest: compounds 2, 1 and 4 (each within the scatter of the next). At a limit, above all of these: compound 3.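

Within the data shown here, this is the first step in which 4-methylphenyl enters on the aromatic carbon of the five-membered aromatic ring with 3 nitrogen and a true number stands at both ends: in this assay the step reads a 1.3-fold higher number from compound 2 to compound 4 (0.10 log units; within the scatter). On the core of compound 2, then, a six-membered aromatic ring with a methyl group can take the place of cyclohex-1-en-1-yl with no difference beyond the scatter, whereas the earlier entry of 4-methylphenyl, on the core of compound 1, ended at a limit and gave no true size. Compound 3 remains the only compound at a limit: the limit of > 100000 nM in this assay, at which 1 of the 4 values shown sits.

Still open, on these data alone, is whether an amine or a carboxylic acid in place of the methyl group of 4-methylphenyl would move the number beyond the scatter. The same question stands for a longer chain joining the ring with 3 nitrogen to the core.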